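The source may report more compounds than this note shows. Statements on the series, on what has been measured and on what is new or still open speak of the compounds shown alone.

Measured compounds:
compound 1 `COc1ccc2occ(CSC(=S)N3CCOCC3)c(=O)c2c1`, 11800 nM
compound 2 `COc1ccc2occ(CSC(=S)N3CCCC3)c(=O)c2c1`, 34100 nM
compound 3 `O=c1c(Cl)c(CSC(=S)N2CCCC2)oc2ccccc12`, 2300 nM

In a functional assay on MCF7 cells (Homo sapiens) for antiproliferative activity, read by MTT assay, with a stated time of 72 h (on this read-out higher numbers stand for weaker inhibition and lower numbers for stronger inhibition), compound 3 gives the lowest number of the three, and compound 2 the highest; both gaps to compound 3 are beyond the scatter. The core of compound 3 and the core of compound 2 are not the same, and the difference between the two cores is not broken down here.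

Compounds 1 and 2 share a core and differ only in one place: morpholin-4-yl in place of pyrrolidin-1-yl on a thiocarbonyl carbon. That change gave a 2.9-fold lower number from compound 2 to compound 1 (0.46 log units; beyond the scatter).

Compound 4 `O=c1c(Cl)c(CSC(=S)N2CCOCC2)oc2ccccc12` is not yet measured. It stands to compound 3 as compound 1 stands to compound 2, through the same change at the same place: morpholin-4-yl in place of pyrrolidin-1-yl on a thiocarbonyl carbon. The earlier step was modest but beyond the scatter. Going by the values given here, with only one example of the change, and on a different core, the step is expected to point the same way but is taken as somewhat smaller, so a 2.1-fold lower number from compound 3 to compound 4 (0.32 log units; beyond the scatter) is expected. On that basis compound 4 is estimated at 1100 nM in this assay, with a range from 450 nM to 2700 nM.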

Compound 4, half-maximal inhibitory concentration: 11100 nM
Compound 4: the middle estimate sits 10-fold (1.00 log units) below what was measured; measured number above the stated range.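

In this assay, morpholin-4-yl in place of pyrrolidin-1-yl on a thiocarbonyl carbon gives a 4.8-fold higher number from compound 3 to compound 4 (0.68 log units; beyond the scatter), and this step does not agree with the earlier one on the other core: the same change on two cores in this assay, a 2.9-fold lower number (0.46 log units; beyond the scatter) from compound 2 to compound 1 and a 4.8-fold higher number (0.68 log units; beyond the scatter) from compound 3 to compound 4, 14-fold (1.14 log units) apart, beyond the scatter of two such steps

In these two matched pairs, the change does not carry over from one core to the other, so a step read on one core predicts neither the direction nor the size of the step on the other. This does not show which feature of the cores goes with the reversal, since they differ in more than one place, and two pairs give no rule for any further core.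

The compounds shown leave open how other amines on the thiocarbonyl carbon, such as piperidin-1-yl or dimethylamino, would behave on either core. Also open, as far as these compounds go, is whether a core carrying only part of the difference between the two cores would follow the step seen with compound 1 and compound 2 or the step seen with compound 3 and compound 4.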